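Amine-bearing substituents on the shared core: compound 4

This account rests on a few compounds, and the source may have more. Where it says the series, first, only, none or still open, it means among the compounds named here.

Within the data shown here, compound 3 `CCCCCCCCCCc1ccc(-c2noc(-c3cccc(CN)c3)n2)cc1` stands lowest of the three numbers so far in an assay on HeLa cells for inhibition of sphingosine-1-phosphate transporter SPNS2 (Mus musculus), read by LC-MS, tested at 2 uM; on this read-out lower numbers stand for less inhibition and higher numbers for more inhibition at the one concentration tested (going by the name of the read-out): compound 3 gives 2%. Compound 1 `CCCCCCCCCCc1ccc(-c2noc(CN)n2)cc1` gives 62%, and compound 2 `CCCCCCCCCCc1ccc(-c2noc(C3CCNC3)n2)cc1` gives 26%. Both steps into compound 3 ran downward, one large, a number 60 percentage points lower from compound 1 to compound 3 (beyond the scatter), and one modest, a number 24 percentage points lower from compound 2 to compound 3 (beyond the scatter); the step between the other two, a number 36 percentage points lower from compound 1 to compound 2 (beyond the scatter), also ran downward.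

Compound 4 `CCCCCCCCCCc1ccc(-c2noc(C(Cl)CCN)n2)cc1` differs from compound 3 at one place: a group of 5 heavy atoms (3 carbon, 1 nitrogen, 1 chlorine; no ring) in place of a group of 8 heavy atoms (7 carbon, 1 nitrogen; one six-membered aromatic ring of carbon only), on an aromatic carbon. Among the measured compounds shown here, the steps that bear on it are the two into compound 3, in which the ring-bearing group entered and the numbers fell. For the measured compounds named here, the change to compound 4 takes that group out again for a smaller group without a ring, so a rise is expected, though the chain with its chlorine has no measured counterpart and the size stays uncertain. In this assay compound 4 is expected to give 35%, with a range from 10% to 65%. The expected step is a number 33 percentage points higher from compound 3 to compound 4 (beyond the scatter).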

Compound 4, a percentage reported as inhibition, at one concentration (the size of the read-out at that concentration, not a potency): 5%
For compound 4 the middle estimate is 30 percentage points above the measured one, outside the stated range (below it).
By their numbers in this assay, from the lowest: compounds 3 and 4 (each within the scatter of the next); then compound 2; then compound 1.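

In this assay, taking out the ring does not bring the number back: the step is a number 3 percentage points higher from compound 3 to compound 4 (within the scatter), so at this aromatic carbon the absence of a ring is not enough on its own. Compound 2 and compound 4 carry groups of the same heavy-atom count, one a ring and one an open chain, yet the step is a number 21 percentage points lower from compound 2 to compound 4 (beyond the scatter), so that count does not fix the number, while the comparison with the small aminomethyl group gives a number 57 percentage points lower from compound 1 to compound 4 (beyond the scatter), leaving aminomethyl above all three larger groups shown. No measured information bears on the reason for these differences.

From the compounds shown here alone, it remains open whether the chlorine or the longer chain accounts for the low number of compound 4. A 3-aminopropyl group without chlorine, or a 2-aminoethyl group, would separate these two changes.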